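A few compounds are considered here, and "the series" means these few. Any claim that something is new, unique, unknown or untested is made for them only; others in the source may bear on it.

Two compounds of the series have been run in a functional assay on CHO cells for antagonist activity at prostaglandin E2 receptor EP3 subtype (Homo sapiens), read by cAMP accumulation; a lower number here means a stronger inhibitor, a higher number a weaker inhibitor. Compound 1 `CC(C)C(c1ccc(-c2ccc3cccc(F)c3c2)[nH]c1=O)N1CCCCS1(=O)=O` gives 122 nM. Compound 2 `CC(C)C(c1ccc(-c2ccc3cccc(F)c3c2)[nH]c1=O)N1CCN/C1=N\C#N` gives 38 nM, the lowest of the two numbers; the step of a 3.2-fold lower number from compound 1 to compound 2 (0.51 log units; beyond the scatter) separates the pair. Compound 3 `CC(C)C(c1nnc[nH]1)c1ccc(-c2ccc3cccc(F)c3c2)[nH]c1=O` is not yet measured. Against compound 2 it carries a group of 5 heavy atoms (2 carbon, 3 nitrogen; one five-membered aromatic ring with 3 hetero atoms) in place of a group of 8 heavy atoms (4 carbon, 4 nitrogen; one five-membered non-aromatic ring with 2 hetero atoms), on a saturated chain carbon bound to an aromatic carbon and a saturated chain carbon. For the measured compounds named here, the only measured step, a 3.2-fold lower number from compound 1 to compound 2 (0.51 log units; beyond the scatter), changed the same saturated chain carbon and shifted the number by a modest amount beyond the scatter, so an exchange at this position is known to register, but no measured compound carries the 4H-1,2,4-triazol-3-yl group and its direction cannot be read from the numbers in hand. For compound 3 a small loss against compound 2 is expected, a 1.8-fold higher number from compound 2 to compound 3 (0.27 log units; within the scatter), with wide uncertainty either way. The estimate for compound 3 in this assay is 70 nM, within 20 nM to 250 nM.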

Compound 3, half-maximal inhibitory concentration: 21 nM
Compound 3: middle estimate off by 3.3-fold (0.52 log units), on the high side; the measured number falls inside the stated range.
By their numbers in this assay, from the lowest: compounds 3 and 2 (each within the scatter of the next); then compound 1.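

In this assay, placing the 4H-1,2,4-triazol-3-yl group on the saturated chain carbon in place of the five-membered non-aromatic ring of compound 2 gives a 1.8-fold lower number from compound 2 to compound 3 (0.26 log units; within the scatter), so these two groups cannot be told apart here, although the entering group has 5 heavy atoms against 8. Against the six-membered non-aromatic ring of compound 1, the same group gives a 5.8-fold lower number from compound 1 to compound 3 (0.76 log units; beyond the scatter), which shows that an aromatic ring at this position can match the better of the two non-aromatic groups. No independent measurement bears on why the two five-membered groups sit so close.

All the compounds shown carry a ring group at this carbon, so it remains open how an open-chain amine or a carboxylic acid would read there. Also open, from the compounds shown here alone, is whether a tetrazole or an imidazole would stay level with the triazole.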